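The source may hold more compounds than are shown below. What is called first, only, known or untested is meant among the compounds shown, and "the series" means these compounds.

In a functional assay on the whole organism for agonist activity, with Mus musculus as the target (a lower number here means that less compound is needed, a higher number that more compound is needed for the effect), compound 1 (`O=C1NCCN1CC#CCn1ccnc1`) gives 30 mg/kg and compound 2 (`CN(C)CC#CCN1CCNC1=O`) gives 9.7 mg/kg, the lower of the two numbers. For the measured compounds named here, the one measured step, a 3.1-fold lower number from compound 1 to compound 2 (0.49 log units; beyond the scatter), is modest and swaps 1H-imidazol-1-yl for dimethylamino on a saturated chain carbon bound to a triple-bonded carbon. Compound 3 (`CN(C)CC#CCN1CCN(C)C1=O`) instead carries methyl in place of hydrogen on an amide-type nitrogen in a ring. Going by the values given here, no measured step touches that place, so the guidance is weak. The expected change in this assay is a 1.6-fold higher number from compound 2 to compound 3 (0.22 log units; within the scatter), a small move to a higher number, not clearly beyond the scatter. For compound 3 the estimated value is 16 mg/kg, with an expected range from 5 mg/kg to 60 mg/kg.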

Compound 3, dose for half-maximal effect: 0.54 mg/kg
Estimate against measurement, compound 3: 30-fold (1.47 log units) above; measured number outside the range, below it.
By their numbers in this assay, from the lowest: compound 3; then compound 2; then compound 1.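

In this assay, for the compounds shown here, methyl in place of the amide hydrogen on the ring nitrogen gives an 18-fold lower number from compound 2 to compound 3 (1.25 log units; beyond the scatter), a large step at a place the earlier compounds left untouched. The amide hydrogen is therefore not required for the effect in this pair, and a single added carbon at this nitrogen matters greatly. No measurement at hand gives a reason for the step. As far as these compounds go, whether ethyl or a longer chain on this nitrogen would lower the number further remains open. So does whether methyl there has the same effect when 1H-imidazol-1-yl replaces dimethylamino.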